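The source may hold more compounds than are shown below. What is called first, only, known or untested is meant among the compounds shown, and "the series" means these compounds.

In an in vitro ADME assay on microsomes from liver (Homo sapiens) for metabolic stability, tested at 5 uM (a lower number here means that the compound disappears faster, a higher number that the compound lasts longer), compound 1 `CS(=O)(=O)Nc1ccc2c(c1)S(=O)(=O)N=C(c1c(O)c(-c3cccs3)nn(CCC3CC3)c1=O)N2` gives > 1 h as a limit of the assay and not as a number. Compound 2 `CCCC(C)n1nc(-c2cccs2)c(O)c(C2=NS(=O)(=O)c3cc(NS(C)(=O)=O)ccc3N2)c1=O` gives > 1 h as a limit too. Compound 3 `CCC(C)n1nc(-c2cccs2)c(O)c(C2=NS(=O)(=O)c3cc(NS(C)(=O)=O)ccc3N2)c1=O` stands at > 1 h as a limit as well. The set as a whole sits at the limit of > 1 h in this assay, at which 3 of the 3 values shown sit, with no number among them.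

Compound 4 `CC(C)(C)Cn1nc(-c2cccs2)c(O)c(C2=NS(=O)(=O)c3cc(NS(C)(=O)=O)ccc3N2)c1=O` has not yet been measured. It differs from compound 3 in carrying neopentyl in place of sec-butyl on an aromatic nitrogen and nothing else.

Among the measured compounds shown here, three measured steps bear on this change, all of them altering the group on that nitrogen: a step that the two limits leave unreadable from compound 1 to compound 3 and a step that the two limits leave unreadable from compound 1 to compound 2 and a step that the two limits leave unreadable from compound 2 to compound 3 give neither a size nor a direction. Each swap left the read-out at the limit, so no step beyond the scatter is expected in either direction. The expectation is a step that the limit leaves unreadable from compound 3 to compound 4 with no direction favoured. Compound 4 is estimated at 1.5 h within an expected range of 0.8 h to 3 h and will probably again be reported only as a limit.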

Compound 4, half-life: > 1 h
Compound 4: only a limit was reported; the forecaster's own chance of this, stated with the estimate: 80%; the middle value does not contradict the limit.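

In this assay compound 4 gives > 1 h, which is a limit of the assay and not a number. Among the compounds shown here, no step between compound 4 and compound 1, compound 2 or compound 3 can therefore be read. The compounds shown leave open how long each actually lasts and whether the group on the aromatic nitrogen matters, as all stand at one limit: the limit of > 1 h in this assay, at which 4 of the 4 values shown sit.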